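The source may hold more compounds than are shown below. What is called first, only, known or untested is meant among the compounds shown, and "the series" means these compounds.

In a functional assay on the whole organism (stomach) with Rattus norvegicus as the target (on this read-out higher numbers stand for an effect only at larger amounts of compound and lower numbers for an effect already at smaller amounts), compound 3 `O=c1ccc(-c2ccccc2)nn1CCCCNC(=S)Nc1ccccc1` gives only a limit, > 100 mg/kg. Compound 2 `CC(C)(C)/N=C(\S)NCCCCn1nc(-c2ccccc2)ccc1=O` likewise gives only a limit in this assay, > 100 mg/kg. Two of the three measured values therefore sit at the limit of > 100 mg/kg in this assay, at which 2 of the 3 values shown sit. Compound 1 `CC/N=C(/NC#N)NCCCCn1nc(-c2ccccc2)ccc1=O` gives a number in this assay, 92 mg/kg. The step to compound 4 `CCC/N=C(/NC#N)NCCCCn1nc(-c2ccccc2)ccc1=O` is a group of 8 heavy atoms (5 carbon, 3 nitrogen; no ring) in place of a group of 9 heavy atoms (7 carbon, 1 nitrogen, 1 sulfur; one six-membered aromatic ring of carbon only), on an amine nitrogen. The closest measured guide runs the other way, an at least 1.0-fold higher number from compound 1 to compound 3 (0.03 log units; that floor lies within the scatter), carrying compound 1 from a number up to the limit; an at least 1.0-fold higher number from compound 1 to compound 2 (0.03 log units; that floor lies within the scatter) points the same way. Compound 4 is expected to come back down to a readable number because compound 1 gives 92 mg/kg with a group close to that of compound 4, a step estimated as an at least 1.1-fold lower number from compound 3 to compound 4 (0.04 log units; that floor lies within the scatter). The estimate for compound 4 is 90 mg/kg, with a range from 45 mg/kg to 180 mg/kg.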

Compound 4, dose for half-maximal effect: > 100 mg/kg
Compound 4: a limit, no number (the forecaster's own chance of this, stated with the estimate: 35%); middle value at least 1.1-fold (0.04 log units) away from the limit.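

In this assay, compound 4 gives only a limit, not a number. The step for methyl in place of hydrogen on a saturated chain carbon, two bonds along the chain from a double-bonded nitrogen, is an at least 1.0-fold higher number from compound 1 to compound 4 (0.03 log units; that floor lies within the scatter), and the steps from the two other limit compounds cannot be read. The limit is thus no longer confined to the sulfur-containing groups: the limit of > 100 mg/kg in this assay, at which 3 of the 4 values shown sit.

Compound 1 remains the only compound with a number, so no change shown has yet improved on it. Going by these compounds, whether a methyl group or a longer chain such as butyl in this place would give a readable number stays open.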